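The source may report more compounds than this note shows. Statements on the series, on what has been measured and on what is new or still open speak of the compounds shown alone.

Compound 1 `Cc1ccc(C(=O)Nc2nc3cc(C)cc(C)c3s2)cc1`: 2.37 ug/mL
Compound 2 `O=C(Nc1cccc([N+](=O)[O-])c1)Nc1nc2ccc(F)cc2s1`: 0.83 ug/mL

Of the compounds shown here, two have been measured in a functional assay on NUGC-3 cells (Homo sapiens) for antiproliferative activity, read by sulforhodamine B assay; a lower number here means a stronger inhibitor of growth, a higher number a weaker inhibitor of growth. Compound 1 gives 2.37 ug/mL, which is the higher of the two numbers; compound 2 gives 0.83 ug/mL, a gap beyond the scatter. The unmeasured compound 3 `COc1ccc(C(=O)Nc2nc3cc(C)cc(C)c3s2)cc1` shares the core of compound 1 and differs from it in one place: methoxy in place of methyl on an aromatic carbon. For the measured compounds named here, no measured pair shows this kind of change, so there is no step to lean on. A swap of this size, with one heavy atom added, would be expected to move the number by little, if at all, and any shift is expected to stay within the scatter in either direction. The step from compound 1 to compound 3 is therefore expected to be a 1.2-fold lower number from compound 1 to compound 3 (0.07 log units; within the scatter). Compound 3 is estimated at 2 ug/mL, in a range from 0.8 ug/mL to 5 ug/mL.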

Compound 3, concentration for 50% growth inhibition: > 10 ug/mL
Compound 3 gave a limit, no number; the forecaster's own chance of this, stated with the estimate: 5%; middle value at least 5.0-fold (0.69 log units) from the limit.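

In this assay, compound 3 gives > 10 ug/mL, which is a limit of the assay and not a number. For the compounds shown here, this is the first measured evidence on this position, para to a large group, and it shows that methoxy in place of methyl on this aromatic carbon does not leave growth inhibition intact, with the change giving an at least 4.2-fold higher number from compound 1 to compound 3 (0.62 log units; beyond the scatter). The weakening is clear, but its full size cannot be read from this result, and the value of compound 3 is the one that rests on the boundary of the read-out: the limit of > 10 ug/mL in this assay, at which 1 of the 3 values shown sits.

The compounds shown leave open whether a hydroxyl, a chlorine or an ethyl group at this same place would retain the activity of compound 1. They also leave open whether methoxy would weaken growth inhibition elsewhere on the core of compound 1.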